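Extending the ester chain on the ring nitrogen of compound 3

The compounds below may be only part of what the source reports. "The series", "measured", "known", "first", "only" and "open" are said of these compounds alone.

Measured compounds:
- Compound 1, `CC(C)(C)OC(=O)CN1CCc2c(sc(NC(=O)Nc3ccc(Cl)cc3)c2C(N)=O)C1`: > 25000 nM in a functional assay (strain AB) with Danio rerio as the target, read by microscopy, with a stated time of 1 h; a higher number here means that more compound is needed for the effect, a lower number that less compound is needed; this value is a limit of the assay, not a number.
- Compound 2, `NC(=O)c1c(NC(=O)Nc2ccc(Cl)cc2)sc2c1CCN(CCCNC(=O)CCc1cccnc1)C2`: 470 nM
- Compound 3, `CN1CCc2c(sc(NC(=O)Nc3ccc(Cl)cc3)c2C(N)=O)C1`: 4700 nM

Compound 3 has the highest of the two numbers in this assay; compound 2 sits with a number a clear gap below it, and compound 1 gives only a limit. Among the measured compounds shown here, the one step in this set that touches the same place is an at least 5.3-fold lower number from compound 1 to compound 3 (0.72 log units; beyond the scatter), so the tert-butoxycarbonyl directly on that carbon is linked with the limit of the limit of > 25000 nM in this assay, at which 1 of the 3 values shown sits.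

Compound 4, `CC(C)(C)OC(=O)CCCCCN1CCc2c(sc(NC(=O)Nc3ccc(Cl)cc3)c2C(N)=O)C1`, differs from compound 3 by 4-(tert-butoxycarbonyl)butyl in place of hydrogen on a saturated chain carbon bound to an amine nitrogen in a ring. The same ester now sits at the far end of a longer chain. For the measured compounds named here, the only direct evidence, the step from compound 1 to compound 3, points toward a higher number; the values of compound 2 and compound 3 show that a longer polar chain on this nitrogen can go with a lower number. These pull in opposite directions, so the estimated step of a 1.2-fold lower number from compound 3 to compound 4 (0.07 log units; within the scatter) is expected to stay small, with wide uncertainty. Compound 4 is therefore estimated at 4000 nM in this assay, within 800 nM to 25000 nM.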

Compound 4, half-maximal effective concentration: 620 nM
Beside the measured number, compound 4's estimate is 6.5-fold (0.81 log units) above it; the whole stated range lies above it.
By their numbers in this assay, from the lowest: compounds 2 and 4 (each within the scatter of the next); then compound 3. At a limit, above all of these: compound 1.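

In this assay, moving the ester away from the ring nitrogen changes the picture: with the 4-(tert-butoxycarbonyl)butyl chain in place of tert-butoxycarbonyl on the same carbon, the data show an at least 40-fold lower number from compound 1 to compound 4 (1.60 log units; beyond the scatter). The ester therefore does not go with a high number wherever it sits, and its place on the chain matters in this pair. The chain also improves on the plain core, with a 7.6-fold lower number from compound 3 to compound 4 (0.88 log units; beyond the scatter), which reverses the direction suggested by the earlier step between compound 1 and compound 3, and the end of the chain need not be a pyridine amide, since a 1.3-fold higher number from compound 2 to compound 4 (0.12 log units; within the scatter) does not separate the two compounds.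

Compound 1 gives only a limit of the assay and not a number, so the true size of the step that starts from it stays open: the limit of > 25000 nM in this assay, at which 1 of the 4 values shown sits. The compounds shown also leave open how much of the gain belongs to the chain and how much to its end, a question that a shorter or longer chain, or a carboxylic acid or an amine in place of the ester, could help to answer.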